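This account rests on a few compounds, and the source may have more. Where it says the series, first, only, none or still open, it means among the compounds named here.

Of the compounds shown here, two on a shared core have been measured in a functional assay on NCI/ADR-RES cells (Homo sapiens) for inhibition, read by sulforhodamine B assay, with a stated time of 48 h; on this read-out lower numbers stand for stronger inhibition of growth and higher numbers for weaker inhibition of growth. Compound 1 `COc1ccc(CNc2nc3cc(N)cc(N)c3nc2-c2ccccc2)cc1OC` gives 17800 nM in this assay. Compound 2 `Nc1cc(N)c2nc(-c3ccccc3)c(NCc3ccc(F)cc3)nc2c1` gives 2450 nM, and so compound 2 stands at the lowest of the two numbers, the stronger growth inhibitor of the pair. Among the measured compounds shown here, the only measured step, a 7.3-fold lower number from compound 1 to compound 2 (0.86 log units; beyond the scatter), swapped one aromatic group for another at the end of the saturated linker, while the linker itself stayed the same.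

Compound 3 `Nc1cc(N)c2nc(-c3ccccc3)c(Oc3ccc(F)cc3)nc2c1` carries a different change: 4-fluorophenoxy in place of (4-fluorobenzyl)amino on an aromatic carbon. Here the attached aromatic group keeps its fluorine but the linker is altered, so the measured step does not address this kind of change, and no measured step bears on it directly. With nothing to guide the direction, only a small move, if any, is expected in this assay, and the range around the estimate is kept wide. Compound 3 is expected to give about 5000 nM, between 1500 nM and 20000 nM, which would mean a step of a 2.0-fold higher number from compound 2 to compound 3 (0.31 log units; beyond the scatter).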

Compound 3, concentration for 50% growth inhibition: 18200 nM
Compound 3: the middle estimate sits 3.6-fold (0.56 log units) below what was measured, and the stated range covers the measured number.
By their numbers in this assay, from the lowest: compound 2; then compounds 1 and 3 (each within the scatter of the next).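

In this assay, putting 4-fluorophenoxy in place of (4-fluorobenzyl)amino on this aromatic carbon gives a 7.4-fold higher number from compound 2 to compound 3 (0.87 log units; beyond the scatter), so growth inhibition at this position depends on how the fluorinated ring is attached to the shared core, and not only on which aromatic group sits at the end, which was all the earlier step could show. The change is more than a swap of one atom: the entering group has 0 hydrogen-bond donors where the leaving group has 1, and 8 heavy atoms where the leaving group has 9, so these differences arrive together and the two compounds cannot tell them apart. Nothing at hand accounts for the weaker inhibition seen with compound 3.

A 4-fluorobenzyloxy group, which keeps the saturated carbon with an oxygen in the chain, and a 4-fluorophenylamino group, which keeps the nitrogen without that carbon, would show which part of the change matters. Also open, as far as these compounds go, is whether a longer chain, such as a 2-(4-fluorophenyl)ethylamino group, would be tolerated at this position.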